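Bromo for Chloro: What the Unmeasured Compound May Give

The compounds below may be only part of what the source reports. "The series", "measured", "known", "first", "only" and "open" are said of these compounds alone.

Of the compounds shown here, three have so far been tested in a functional assay on the whole organism for inhibition, with Rattus norvegicus as the target, read by paw edema, with a stated time of 30 min, at a dose of 40 mg/kg by the oral route; a higher number here means a stronger effect of the compound at the dose given, a lower number a weaker effect. Compound 1 `Clc1ccc(OCC2=NCCO2)cc1` gives 48.2%, the highest of the three numbers. Compound 2 `Brc1ccccc1OCC1=NCCO1` gives 29.1%, and compound 3 `Clc1ccccc1OCC1=NCCO1` gives 22.2%. Compound 2 and compound 3 share a core and differ in one place: bromo in place of chloro on an aromatic carbon This exchange made a step of a number 6.9 percentage points higher from compound 3 to compound 2 (within the scatter), so the two numbers cannot be told apart with confidence.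

Compound 1 and compound 3 are built from the same atoms joined differently, and the difference between the two cores is not broken down here.

Compound 4 `Brc1ccc(OCC2=NCCO2)cc1` has not yet been measured in this assay. Within the data shown here, it differs from compound 1 in one place: bromo in place of chloro on an aromatic carbon This is the same kind of change as the one from compound 3 to compound 2, but not the same change: there the place is ortho to a group of 7 heavy atoms, here it is para to a group of 7 heavy atoms. Among the measured compounds shown here, the only measured example of this kind of change gave a step within the scatter, and that single example is the whole basis for what follows. On that basis a step of a number 2.8 percentage points higher from compound 1 to compound 4 (within the scatter) is expected. Compound 4 is therefore expected to give about 51% in this assay, with a likely range from 36% to 66%.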

Compound 4, a percentage reported as inhibition, in the whole organism at one dose (the size of the read-out at that dose, not a potency): 48.5%
Compound 4: the middle estimate sits 2.5 percentage points above what was measured; the measured number falls inside the stated range.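

Putting bromo in place of chloro on the core of compound 1 made a step of a number 0.3 percentage points higher from compound 1 to compound 4 (within the scatter), so in this assay these two compounds cannot be told apart. Set beside the earlier case, the same exchange reads alike on the two cores: the same change on two cores in this assay, a number 6.9 percentage points higher (within the scatter) from compound 3 to compound 2 and a number 0.3 percentage points higher (within the scatter) from compound 1 to compound 4, 6.6 percentage points apart, within the scatter of two such steps This shows that, on these two cores and at this single dose, the exchange has not moved the read-out by more than repeated measurements would, but it does not show that bromo and chloro are interchangeable on any other core, since two pairs are a small basis and neither one says why the numbers came out as they did.

The compounds shown carry only chloro or bromo on the aromatic ring, so it remains open whether a different group in that place, such as fluoro, methoxy, a nitrile or a carboxylic acid, would leave the read-out where it stands or shift it clearly. Going by these compounds, it also remains open whether a plain hydrogen there, with no halogen at all, would give a number that can be told apart from those of the chloro and bromo compounds.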